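A single change at the carbonyl carbon

This account rests on a few compounds, and the source may have more. Where it says the series, first, only, none or still open, it means among the compounds named here.

Measured compounds:
compound 1 `O=C(Nc1cccc(-n2cc(-c3ccncc3)c(-c3cc(O)cc(Cl)c3)n2)c1)Nc1ccc(Cl)c(C(F)(F)F)c1`: 91%
compound 2 `COc1cc(Cl)cc(-c2nn(-c3cccc(NC(=O)Nc4ccc(Cl)c(C(F)(F)F)c4)c3)cc2-c2ccncc2)c1`: 59%

Among the measured compounds shown here, in a functional assay on UACC-257 cells (Homo sapiens) for inhibition, read by sulforhodamine B assay, with a stated time of 48 h, tested at 0.1 uM (a higher number here means a weaker effect of the compound at the concentration tested, a lower number a stronger effect), compound 2 gives 59%, the lowest of the two numbers known here; its nearest neighbour is compound 1, which gives 91% in this assay. For the measured compounds named here, the only measured step is a number 32 percentage points lower from compound 1 to compound 2 (beyond the scatter), which came with methyl in place of hydrogen on an oxygen on an aromatic ring.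

Compound 3 `COc1cc(Cl)cc(-c2nn(-c3cccc(NC(=O)c4cccc(C(F)(F)F)c4)c3)cc2-c2ccncc2)c1` has not been measured in this assay. Its difference from compound 2 is 3-(trifluoromethyl)phenyl in place of (4-chloro-3-(trifluoromethyl)phenyl)amino on a carbonyl carbon. Going by the values given here, no measured step touches this part of the molecule: the one known step alters a group on a ring far from the carbonyl carbon, so it gives no guide to the direction or size of the step from compound 2 to compound 3. With nothing in the data speaking for a gain, and the loss of the amide hydrogen on that side untested, a modest weakening is the more cautious expectation, with wide uncertainty. The expected step is a number 13 percentage points higher from compound 2 to compound 3 (beyond the scatter). For compound 3 the estimate in this assay is 72%, with a range from 48% to 96%.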

Compound 3, a percentage reported as activity, at one concentration (the size of the read-out at that concentration, not a potency): 91%
Compound 3: middle estimate off by 19 percentage points, on the low side; the range from low to high includes it.
By their numbers in this assay, from the lowest: compound 2; then compounds 1 and 3 (each within the scatter of the next).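

In this assay, putting 3-(trifluoromethyl)phenyl on the carbonyl carbon in place of (4-chloro-3-(trifluoromethyl)phenyl)amino gave a number 32 percentage points higher from compound 2 to compound 3 (beyond the scatter). Among the compounds shown here, this is the first sign that the group on the carbonyl carbon matters for this read-out, and the change takes the effect of compound 2 away about as far as the earlier step on the aromatic oxygen had added to it. That earlier step, a number 32 percentage points lower from compound 1 to compound 2 (beyond the scatter), lies at another place in the molecule, so the two steps together show that the read-out responds to changes at both places; no measurement here explains why the change at the carbonyl carbon weakens the effect.

The step changes several things at once: the amino nitrogen with its hydrogen-bond donor goes, and so does the chlorine, so it remains open which of them accounts for the loss. A 3-(trifluoromethyl)phenylamino group or a 4-chloro-3-(trifluoromethyl)phenyl group on the carbonyl carbon would separate these, and a methylene in place of the amino nitrogen would test whether that nitrogen is needed at all.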